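Testing a Methoxyphenyl Change in a Weakly Active Series

The source may report more compounds than this note shows. Statements on the series, on what has been measured and on what is new or still open speak of the compounds shown alone.

Compound 1 `Fc1ccc(C2=NN(C(=S)Nc3ccccc3)C(c3ccc4c(c3)OCCO4)C2)cc1`: in a functional assay on WM 266-4 cells (Homo sapiens) for antiproliferative activity, read by MTT assay, with a stated time of 48 h (on this read-out higher numbers stand for weaker inhibition of growth and lower numbers for stronger inhibition of growth), compound 1 gives 22500 nM.
Compound 2 `S=C(Nc1ccccc1)N1N=C(c2ccc(Cl)cc2)CC1c1ccc2c(c1)OCCO2`: compound 2 returns only the limit of the assay, > 200000 nM.
Compound 3 `S=C(Nc1ccccc1)N1N=C(c2cccc(Cl)c2)CC1c1ccc2c(c1)OCCO2`: compound 3 also returns only the limit of the assay, > 200000 nM.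

Compound 2 therefore stands at the edge of what this assay can report, and it shares that position with one other compound (the limit of > 200000 nM in this assay, at which 2 of the 3 values shown sit). Both changes made from compound 1 weakened growth inhibition clearly: an at least 8.8-fold higher number from compound 1 to compound 2 (0.94 log units; beyond the scatter) and an at least 8.8-fold higher number from compound 1 to compound 3 (0.94 log units; beyond the scatter). Between the two limit compounds the step cannot be read: a step that the two limits leave unreadable from compound 2 to compound 3.

Compound 4 `COc1cccc(C2=NN(C(=S)Nc3ccccc3)C(c3ccc4c(c3)OCCO4)C2)c1` differs from compound 2 by 3-methoxyphenyl in place of 4-chlorophenyl on a carbon with a double bond to nitrogen. Among the measured compounds shown here, the only earlier move to a 3-substituted phenyl, from compound 1 to compound 3, ended at the limit, and the only numbered value belongs to the 4-fluorophenyl compound 1. Compound 4 is therefore expected to stay weak, with a step of an at least 2.0-fold lower number from compound 2 to compound 4 (0.30 log units; that floor lies within the scatter) that cannot be fixed firmly because compound 2 sits at the limit (the limit of > 200000 nM in this assay, at which 2 of the 3 values shown sit). Compound 4 is estimated at 100000 nM, between 20000 nM and 300000 nM.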

Compound 4, concentration for 50% growth inhibition: 1380 nM
The estimate for compound 4 lay 72-fold (1.86 log units) above the measured number; measured number below the stated range.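

The 3-substituted phenyl is not a problem in itself: keeping that position and putting methoxy in place of chloro gives an at least 140-fold lower number from compound 3 to compound 4 (2.16 log units; beyond the scatter), so the outcome in this assay depends on the group and not only on where it sits. Among the compounds shown here, the 3-methoxyphenyl also improves on the only earlier compound with a numbered value, with a 16-fold lower number from compound 1 to compound 4 (1.21 log units; beyond the scatter), and replacing the 4-chlorophenyl gives an at least 140-fold lower number from compound 2 to compound 4 (2.16 log units; beyond the scatter). The steps from compound 2 and compound 3 are minimum sizes, not exact ones, as each starts from a limit of the assay: the limit of > 200000 nM in this assay, at which 2 of the 4 values shown sit.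

On these data alone, it remains open whether a 4-methoxyphenyl, a 3-ethoxyphenyl or a 3-aminophenyl on this carbon would keep the gain. The compounds shown also cannot tell why methoxy and chloro differ so widely here.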